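Halogen swap at the aromatic ring: from iodo to fluoro

This account rests on a few compounds, and the source may have more. Where it says the series, first, only, none or still open, it means among the compounds named here.

Measured so far:
compound 1 `O=C(O)/C(S)=C/c1ccccc1Cl`: 11900 nM
compound 2 `O=C(O)/C(S)=C/c1ccccc1I`: 29600 nM

Two compounds share one core and differ only in the halogen on the aromatic ring. In an assay on isolated protein for inhibition of Calpain-1 catalytic subunit (Sus scrofa), read by FRET (a lower number here means a stronger inhibitor, a higher number a weaker inhibitor), compound 1 gives 11900 nM, while compound 2 gives 29600 nM, the higher of the two numbers. Among the compounds with values here, the one measured step, a 2.5-fold higher number from compound 1 to compound 2 (0.40 log units; beyond the scatter), was brought about by iodo in place of chloro on an aromatic carbon.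

Compound 3 `O=C(O)/C(S)=C/c1ccccc1F` carries the third halogen. The change fluoro in place of iodo on an aromatic carbon is the only one that bears on it, and the measured step points the other way: moving from chloro to iodo raised the number, so moving from iodo to fluoro is expected to lower it, by about a 3.3-fold lower number from compound 2 to compound 3 (0.52 log units; beyond the scatter). Compound 3 is therefore estimated at 9000 nM in this assay, within a range from 3000 nM to 30000 nM, with the caveat that a single step is a thin basis.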

Compound 3, half-maximal inhibitory concentration: 21900 nM
Compound 3: middle estimate off by 2.4-fold (0.39 log units), on the low side; the measured number falls inside the stated range.
By their numbers in this assay, from the lowest: compounds 1, 3 and 2 (each within the scatter of the next, the first and the last beyond it).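

Read in this assay fluoro in place of iodo on the aromatic carbon gives a 1.4-fold lower number from compound 2 to compound 3 (0.13 log units; within the scatter) and fluoro in place of chloro gives a 1.8-fold higher number from compound 1 to compound 3 (0.26 log units; within the scatter). Compound 3 therefore cannot be told apart from either of the other two, so the one gap beyond the scatter, between compound 1 and compound 2, does not grow into a trend across the three halogens. Nothing available explains the small spread at this position.

The compounds shown leave open whether anything other than a halogen at this place, such as an amine, a methoxy group or a carboxylic acid, would move the number further. They also leave open how the core behaves with only a hydrogen on this aromatic carbon.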